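Aryl swap on the benzyl arm: cytotoxicity working notes

This account rests on a few compounds, and the source may have more. Where it says the series, first, only, none or still open, it means among the compounds named here.

Measured so far in an ADME assay on MT4 cells (Homo sapiens) for cytotoxicity; on this read-out lower numbers stand for higher toxicity in this test and higher numbers for lower toxicity in this test:
- compound 1, `COC(=O)N[C@H](C(=O)NN(CCC[C@@](O)(Cc1ccccc1)C(=O)N[C@H]1c2ccccc2C[C@H]1O)Cc1ccc(-c2cncnc2)cc1)C(C)(C)C`, gives > 10000 nM, a limit of the test rather than a number.
- compound 2, `COC(=O)N[C@H](C(=O)NN(CCC[C@@](O)(Cc1ccccc1)C(=O)N[C@H]1c2ccccc2C[C@H]1O)Cc1ccc(-n2ccnc2)cc1)C(C)(C)C`, gives > 10000 nM, likewise a limit.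
- compound 3, `COC(=O)N[C@H](C(=O)NN(CCC[C@@](O)(Cc1ccccc1)C(=O)N[C@H]1c2ccccc2C[C@H]1O)Cc1ccc(I)cc1)C(C)(C)C`, gives > 10000 nM, again a limit.

For the measured compounds named here, compound 1 therefore has no fixed position on this read-out; it sits at the cap of the test, and the same holds for the other two, so that the limit of > 10000 nM in this assay, at which 3 of the 3 values shown sit, is the only evidence the series offers. The steps among them, a step that the two limits leave unreadable from compound 1 to compound 2, a step that the two limits leave unreadable from compound 1 to compound 3 and a step that the two limits leave unreadable from compound 2 to compound 3, cannot be sized from two limits.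

Compound 4, `COC(=O)N[C@H](C(=O)NN(CCC[C@@](O)(Cc1ccccc1)C(=O)N[C@H]1c2ccccc2C[C@H]1O)Cc1ccc(-c2cccnc2)cc1)C(C)(C)C`, is yet to be run in this assay. It differs from compound 1 by pyridin-3-yl in place of pyrimidin-5-yl on an aromatic carbon. The measured steps bear on it only in that three exchanges at this same position, each well beyond a nitrogen count or halogen swap, all left the read-out at the limit. No step in either direction beyond the scatter is expected for the exchange from compound 1 to compound 4, and the most likely outcome is that compound 4 again returns a limit. Compound 4 is estimated at 10000 nM, within 5000 nM to 20000 nM, which means an expected step of a number no higher from compound 1 to compound 4 (the limit leaves the size open).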

Compound 4, half-maximal cytotoxic concentration: > 10000 nM
Compound 4: only a limit was reported; the forecaster's own chance of this, stated with the estimate: 85%; the middle value lies on the limit itself.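

In this assay compound 4 gives > 10000 nM, again a limit of the test and not a number. No step linking compound 4 to compound 1, compound 2 or compound 3 can be read: the limit of > 10000 nM in this assay, at which 4 of the 4 values shown sit.

The compounds shown leave open where the true value of each lies beyond that limit, and so whether the four differ at all.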